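The compounds below may be only part of what the source reports. "The series", "measured", "known", "first", "only" and "open" are said of these compounds alone.

Measured in an ADME assay on CHO cells (Cricetulus griseus) for cytotoxicity, read by MTT assay; on this read-out lower numbers stand for higher toxicity in this test and higher numbers for lower toxicity in this test:
- compound 1 `CN1CCN(CC2CCN(c3nccc4[nH]c(-c5ccc(F)c(F)c5)nc34)CC2)CC1`: 7400 nM
- compound 2 `Fc1ccc(-c2nc3c(N4CCC(N5CCNCC5)CC4)nccc3[nH]2)cc1C(F)(F)F`: 34000 nM

Compound 2 holds the higher of the two numbers, and compound 1 lies below it by more than the scatter. Compound 3 `CN1CCN(CC2CCN(c3nccc4[nH]c(-c5ccc(F)c(C(F)(F)F)c5)nc34)CC2)CC1` differs from compound 2 as follows: (4-methylpiperazin-1-yl)methyl in place of piperazin-1-yl on a saturated ring carbon. Among the compounds with values here, no single-change step has been measured. Compound 1 carries the same (4-methylpiperazin-1-yl)methyl and gives 7400 nM, so a downward step is expected in this assay. The estimated 3.4-fold lower number from compound 2 to compound 3 (0.53 log units; beyond the scatter) is a moderate one, beyond the scatter. For compound 3 the expected value is 10000 nM, with an estimated range of 4000 nM to 28000 nM.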

Compound 3, half-maximal cytotoxic concentration: 3100 nM
For compound 3 the middle estimate is 3.2-fold (0.51 log units) above the measured one; measured number outside the range, below it.
By their numbers in this assay, from the lowest: compound 3; then compound 1; then compound 2.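

In this assay, (4-methylpiperazin-1-yl)methyl in place of piperazin-1-yl on the saturated ring carbon gives a large step (an 11-fold lower number from compound 2 to compound 3 (1.04 log units; beyond the scatter)), toward higher toxicity in this test. With that group held fixed, trifluoromethyl in place of fluoro on the aromatic carbon gives a modest step in the same direction (a 2.4-fold lower number from compound 1 to compound 3 (0.38 log units; beyond the scatter)), so both places move the read-out, the saturated ring carbon by more. Nothing measured here bears on the reason for either step.

From the compounds shown here alone, whether the larger step belongs to the added methyl on the ring nitrogen or to the added methylene link remains open. Going by these compounds, how a morpholin-4-yl or a dimethylamino group on that ring carbon reads also remains open.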